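The source may hold more compounds than are shown below. What is called first, only, known or untested is meant among the compounds shown, and "the series" means these compounds.

Three compounds have been measured in a functional assay on A549 cells (Homo sapiens) for cytotoxicity, read by MTT assay, with a stated time of 72 h; a lower number here means a stronger inhibitor, a higher number a weaker inhibitor:

Compound 1 `CNC(=O)c1cc(Oc2ccc(NC(=O)c3nn(-c4ccccc4C(F)(F)F)c(=O)cc3C)cc2F)ccn1`: in this assay compound 1 gives > 40000 nM, which is a limit of the assay rather than a number.
Compound 2 `Cc1cc(=O)n(-c2cccc(F)c2)nc1C(=O)Nc1ccc(Oc2ncnc3ccsc23)cc1`: in this assay compound 2 gives 9540 nM.
Compound 3 `Cc1cc(=O)n(-c2ccccc2C(F)(F)F)nc1C(=O)Nc1ccc(Oc2ncnc3ccsc23)c(F)c1`: in this assay compound 3 gives 4680 nM.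

Of the two numbers actually obtained, compound 3 has the lower and compound 2 the higher. Within the data shown here, the only measured step that changes one place at a time is an at least 8.5-fold lower number from compound 1 to compound 3 (0.93 log units; beyond the scatter), and it concerns the ring system on the ether oxygen, not the group on the aromatic nitrogen.

Compound 4 `Cc1cc(=O)n(-c2cccc(F)c2)nc1C(=O)Nc1ccc(Oc2ncnc3ccsc23)c(F)c1` differs from compound 3 in 3-fluorophenyl in place of 2-(trifluoromethyl)phenyl on an aromatic nitrogen. Among the measured compounds shown here, no measured step isolates this change: compounds 2 and 3 differ in two places at once, so their values cannot be split between them. With nothing bearing directly on it, the expected outcome is a number close to that of compound 3, perhaps somewhat higher, so that a 1.4-fold higher number from compound 3 to compound 4 (0.14 log units; within the scatter) is expected. Compound 4 is therefore estimated at 6500 nM, with a range from 2500 nM to 17000 nM.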

Compound 4, half-maximal inhibitory concentration: 5220 nM
Compound 4: the middle estimate sits 1.2-fold (0.10 log units) above what was measured, and the stated range covers the measured number.
By their numbers in this assay, from the lowest: compounds 3, 4 and 2 (each within the scatter of the next, the first and the last beyond it). At a limit, above all of these: compound 1.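

In this assay the change on the aromatic nitrogen can now be read on its own: 3-fluorophenyl in place of 2-(trifluoromethyl)phenyl gives a 1.1-fold higher number from compound 3 to compound 4 (0.05 log units; within the scatter) and so, at this position, the two groups cannot be told apart, although the entering group has fewer heavy atoms. The second new step isolates fluoro in place of hydrogen on an aromatic carbon, and a 1.8-fold lower number from compound 2 to compound 4 (0.26 log units; within the scatter) again leaves the two compounds indistinguishable. Nothing measured here offers a reason for either result.

As far as these compounds go, both groups seen on this nitrogen in these pairs are fluorine-bearing phenyl rings, so it remains open whether a phenyl ring carrying an amine or a carboxylic acid would shift the number at all. Also open, from the compounds shown here alone, is whether the same exchange would behave alike on the core of compound 1, which has no such partner here.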